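Lengthening a Side Chain on Two Related Lactams

The compounds below may be only part of what the source reports. "The series", "measured", "known", "first", "only" and "open" are said of these compounds alone.

The three measured compounds share a small saturated ring bearing a carbonyl, with a short unsaturated chain hanging from a ring carbon and a larger group on the ring nitrogen. Compound 1 `C=CCCC1CN([Si](C)(C)C(C)(C)C)C1=O` carries a silicon-based group on the nitrogen, and in an assay for inhibition of Fatty-acid amide hydrolase 1 (Homo sapiens), tested at 1 mM (a lower number here means less inhibition, a higher number more inhibition at the concentration tested (going by the name of the read-out)), compound 1 gives 49.5%. Compound 2 `C=CCCCC1CN([Si](C)(C)C(C)(C)C)C1=O` keeps that nitrogen group and differs only by allyl in place of vinyl on a saturated chain carbon, two bonds along the chain from a saturated ring carbon; in this assay compound 2 gives 76.9%, so the step of a number 27.4 percentage points higher from compound 1 to compound 2 (beyond the scatter). Compound 3 `C=CCCC(=O)N1CC(CCC=C)C1=O` instead carries an unsaturated acyl group on the nitrogen, and in this assay compound 3 gives 103%, the highest of the three. The difference between the core of compound 1 and the core of compound 3 is not broken down here.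

Compound 4 `C=CCCCC1CN(C(=O)CCC=C)C1=O` has not yet been measured. It differs from compound 3 by allyl in place of vinyl on a saturated chain carbon, two bonds along the chain from a saturated ring carbon, the same change, made in the same place, as that between compound 1 and compound 2; among the compounds shown it occurs twice. The earlier step was modest but beyond the scatter. Compound 3, however, already has the highest number of the three in this assay, so the same change is expected to move the number much less, giving an expected step of a number 3 percentage points lower from compound 3 to compound 4 (within the scatter). On that basis, compound 4 is estimated to reach 100%, with an expected range from 88% to 106%.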

Compound 4, a percentage reported as inhibition, at one concentration (the size of the read-out at that concentration, not a potency): 101%
The estimate for compound 4 lay 1 percentage points below the measured number, and the stated range covers the measured number.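

In this assay, putting allyl in place of vinyl on the core of compound 3 gives a number 2 percentage points lower from compound 3 to compound 4 (within the scatter), so the rise seen on the core of compound 1 does not reappear here. The same change therefore cannot be carried from one core to the other in this series with its size assumed to stay the same: the same change on two cores in this assay, a number 27.4 percentage points higher (beyond the scatter) from compound 1 to compound 2 and a number 2 percentage points lower (within the scatter) from compound 3 to compound 4, 29.4 percentage points apart, beyond the scatter of two such steps

This does not show what causes the difference, since it rests on a single pair of compounds on each core, and each number is a percentage at one concentration rather than a potency; the data cannot say whether the group on the nitrogen decides the outcome or whether a number such as the 103% of compound 3 simply leaves little room to rise.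

The compounds shown leave open how a longer chain, such as but-3-en-1-yl or pent-4-en-1-yl in the same place, would read on either core. They also leave open whether a different group on the nitrogen, such as a simple acetyl group, would follow the pattern of the silicon-based group or that of the unsaturated acyl group.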